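Series notes: from compound 2 to compound 3

This account rests on a few compounds, and the source may have more. Where it says the series, first, only, none or still open, it means among the compounds named here.

- compound 1 `Nc1ccccc1NC(=O)c1ccc(Cn2cnc3c(NCc4ccccc4)nc(Cl)nc32)cc1`: 6770 nM
- compound 2 `CC1CCN(c2nc(Cl)nc3c2ncn3Cc2ccc(C(=O)Nc3ccccc3N)cc2)CC1`: 4500 nM
- compound 3 `CN1CCN(c2nc(Cl)nc3c2ncn3Cc2ccc(C(=O)Nc3ccccc3N)cc2)CC1`: not yet measured

In a functional assay on HeLa cells (Homo sapiens) for antiproliferative activity, read by CCK-8 assay, with a stated time of 72 h (on this read-out higher numbers stand for weaker inhibition and lower numbers for stronger inhibition), compound 2 gives 4500 nM, which lies within the scatter of compound 1 at 6770 nM, so no order can be drawn between the two. Compound 3 carries 4-methylpiperazin-1-yl in place of 4-methylpiperidin-1-yl on an aromatic carbon. Among the compounds with values here, no measured pair tests this exchange directly. Within the data shown here, the only measured step, which also changes the group on an aromatic carbon, is a 1.5-fold lower number from compound 1 to compound 2 (0.18 log units; within the scatter). Among the measured compounds shown here, with so small a step as the sole guide, no change beyond the scatter is expected in this assay, in either direction. The expected step is a 1.1-fold higher number from compound 2 to compound 3 (0.05 log units; within the scatter). The estimate for compound 3 is 5000 nM, with an expected range from 1800 nM to 12000 nM.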

Compound 3, half-maximal inhibitory concentration: 1170 nM
Estimate against measurement, compound 3: 4.3-fold (0.63 log units) above, and the stated range ends above it.
By their numbers in this assay, from the lowest: compound 3; then compounds 2 and 1 (each within the scatter of the next).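

In this assay, 4-methylpiperazin-1-yl in place of 4-methylpiperidin-1-yl gives a 3.8-fold lower number from compound 2 to compound 3 (0.59 log units; beyond the scatter) on this aromatic carbon, so the position responds beyond the scatter, which the step between compounds 1 and 2 did not show. The two groups have the same heavy-atom count and differ by one ring atom, nitrogen for carbon, so a single atom of the group is enough to move the number here. Against benzylamino, the same entering group gives a 5.8-fold lower number from compound 1 to compound 3 (0.76 log units; beyond the scatter) in this assay, and nothing measured here accounts for either step.

Open, on these data alone, is whether the second ring nitrogen alone carries the step: morpholin-4-yl or unsubstituted piperazin-1-yl on the same carbon would test that. Also open, as far as these compounds go, is whether the step holds with an amine in place of the chloro group.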